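Aryl swap on the amide-type nitrogen: working notes

The compounds below may be only part of what the source reports. "The series", "measured", "known", "first", "only" and "open" are said of these compounds alone.

Values in an ADME assay on MT4 cells (Homo sapiens) for cytotoxicity, read by MTT assay, with a stated time of 4 days; on this read-out lower numbers stand for higher toxicity in this test and higher numbers for lower toxicity in this test:
- compound 1 `Cc1cc(C#N)cc(C)c1Oc1ccnc(SCC(=O)Nc2ccc(C#N)cc2)n1`: > 300000 nM (a limit of the assay, not a number)
- compound 2 `COc1ccc(NC(=O)CS(=O)(=O)c2nccc(Oc3c(C)cc(C#N)cc3C)n2)cc1`: 5110 nM

Within the data shown here, compound 2, at 5110 nM, holds the only actual number so far. Compound 1 stands at a limit, > 300000 nM, and gives no number.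

Next in line is compound 3 `Cc1cc(C#N)cc(C)c1Oc1ccnc(S(=O)(=O)CC(=O)Nc2cccc(Cl)c2)n1`, not yet measured in this assay. It carries 3-chlorophenyl in place of 4-methoxyphenyl on an amide-type nitrogen. Among the measured compounds shown here, no measured step shows the size of such a change. Nothing else differs, so compound 3 is expected to stay close to compound 2 at 5110 nM. The expected step of a 1.2-fold higher number from compound 2 to compound 3 (0.07 log units; within the scatter) lies within the usual scatter, with no direction expected. For compound 3 the estimated half-maximal cytotoxic concentration is 6000 nM, with an expected range from 2000 nM to 20000 nM.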

Compound 3, half-maximal cytotoxic concentration: 25400 nM
Beside the measured number, compound 3's estimate is 4.2-fold (0.63 log units) below it, and the stated range ends below it.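

In this assay, the aryl group on the amide-type nitrogen proves able to shift the read-out: 3-chlorophenyl in place of 4-methoxyphenyl gives a 5.0-fold higher number from compound 2 to compound 3 (0.70 log units; beyond the scatter), toward lower toxicity in this test. Among these compounds, this is the only readable step, so the size of the effect at this place rests on a single pair, and the step is a modest one. Compound 1 holds a limit rather than a number and enters no step: the limit of > 300000 nM in this assay, at which 1 of the 3 values shown sits.

The swap changes both the substituent and its place on the phenyl ring, so 3-methoxyphenyl and 4-chlorophenyl are the groups that would separate those two changes. One step also leaves open how far the number can move at this place, for instance with a carboxylic acid on the phenyl ring.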